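Side-chain amine variation on the shared core

The source may report more compounds than this note shows. Statements on the series, on what has been measured and on what is new or still open speak of the compounds shown alone.

Compound 1 `CN(CC1CCCCC1)CC1(O)CCN(CCCc2c[nH]c3ccc(-n4cnnc4)cc23)CC1`: 1.2 nM
Compound 2 `CC(C)(C)OC(=O)NCC1(O)CCN(CCCc2c[nH]c3ccc(-n4cnnc4)cc23)CC1`: 21 nM
Compound 3 `CN(Cc1ccccc1)CC1(O)CCN(CCCc2c[nH]c3ccc(-n4cnnc4)cc23)CC1`: 1.2 nM

In an assay on CHO cells with 5-hydroxytryptamine receptor 1D (Homo sapiens) as the target (on this read-out lower numbers stand for stronger inhibition and higher numbers for weaker inhibition), compound 3 stands level with compound 1 at the digits printed, the two together at the low end of the three numbers, while compound 2 is furthest off, with an 18-fold lower number from compound 2 to compound 3 (1.24 log units; beyond the scatter) on the way back to compound 3.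

Compound 4 `Cc1ccccc1CNCC1(O)CCN(CCCc2c[nH]c3ccc(-n4cnnc4)cc23)CC1` differs from compound 3 in one place: (2-methylbenzyl)amino in place of benzyl(methyl)amino on a saturated chain carbon bound to a saturated ring carbon.

Within the data shown here, two measured steps bear on this. The swap of cyclohexyl for phenyl gave no change at the digits printed from compound 1 to compound 3 (within the scatter), so the aromatic part tolerates change. The step of an 18-fold higher number from compound 1 to compound 2 (1.24 log units; beyond the scatter) shows that losing the amine for a carbamate costs a great deal; compound 4 keeps an amine, only without its methyl. A step of modest size at most is therefore expected, a 2.1-fold higher number from compound 3 to compound 4 (0.32 log units; beyond the scatter), and compound 4 is estimated at 2.5 nM with a range of 0.7 nM to 9 nM.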

Compound 4, half-maximal inhibitory concentration: 4 nM
Compound 4: middle estimate off by 1.6-fold (0.20 log units), on the low side; the measured number falls inside the stated range.
By their numbers in this assay, from the lowest: compounds 1 and 3 (each within the scatter of the next); then compound 4; then compound 2.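

In this assay the position takes a hydrogen-bond donor on the amine at a modest price, with a 3.3-fold higher number from compound 3 to compound 4 (0.52 log units; beyond the scatter) and a 3.3-fold higher number from compound 1 to compound 4 (0.52 log units; beyond the scatter) as the two readings of that price. Even so, 2-methylbenzyl in place of tert-butoxycarbonyl on an amine nitrogen gives a 5.3-fold lower number from compound 2 to compound 4 (0.72 log units; beyond the scatter) and so recovers much of what the carbamate lost. No measured evidence explains these shifts.

The step from compound 3 to compound 4 changes the methyl on nitrogen and the methyl on the ring together, so the two contributions remain unseparated. A plain benzylamino group or a (2-methylbenzyl)(methyl)amino group would separate them.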